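Solubility notes on the ethyl ester series: compound 4

The compounds below may be only part of what the source reports. "The series", "measured", "known", "first", "only" and "open" are said of these compounds alone.

Measured so far in a physicochemical assay for solubility, in phosphate buffer, at pH 7.4; a higher number here means a more soluble compound, a lower number a less soluble compound:
Compound 1 `CCOC(=O)c1c(-c2ccc(OC)cc2)[nH]c2cc(OC)ccc2c1=O`: 8000 nM
Compound 2 `CCOC(=O)c1c(-c2ccc(Cl)cc2)[nH]c2cccc(OC)c2c1=O`: > 100000 nM
Compound 3 `CCOC(=O)c1c(-c2ccc(C(C)(C)C)cc2)[nH]c2cccc(OC)c2c1=O`: 1000 nM

Compound 2 stands at the limit of > 100000 nM in this assay, at which 1 of the 3 values shown sits; its value is a limit of this assay, not a number. Compound 4 `CCOC(=O)c1c(-c2cccc(F)c2)[nH]c2cccc(OC)c2c1=O` differs from compound 2 in one place: 3-fluorophenyl in place of 4-chlorophenyl on an aromatic carbon. Going by the values given here, the only measured step on the pendant phenyl is an at least 100-fold lower number from compound 2 to compound 3 (2.00 log units; beyond the scatter); it replaces the same chloro but with a different group, so it bears on compound 4 only loosely. Among the compounds with values here, no measured step covers fluoro or a 3-substituted phenyl. Compound 4 is therefore expected to stay near the limit, with an expected step of a number no higher from compound 2 to compound 4 (the limit leaves the size open). The estimate for compound 4 in this assay is 100000 nM, in the range 30000 nM to 300000 nM.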

Compound 4, solubility: > 100000 nM
Compound 4 ended at the assay's limit; the forecaster's own chance of this, stated with the estimate: 50%; the middle value sits exactly at the limit.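

Compound 2 and compound 4 both sit at a limit of this assay, and no step between them can be read: the limit of > 100000 nM in this assay, at which 2 of the 4 values shown sit.

The compounds shown leave open whether 3-fluorophenyl and 4-chlorophenyl differ at all in this assay, and if so, which gives the higher number.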